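Taking One Methyl Off: What the Liver Read-out May Show

A few compounds are considered here, and "the series" means these few. Any claim that something is new, unique, unknown or untested is made for them only; others in the source may bear on it.

Compound 1 `Cc1cc(C)[n+]([O-])c(Cl)c1-c1noc(-c2cc(O)c(O)c([N+](=O)[O-])c2)n1` gives 13.9%.
Compound 2 `Cc1c(C)c(C)[n+]([O-])c(Cl)c1-c1noc(-c2cc(O)c(O)c([N+](=O)[O-])c2)n1` gives 7.9%.
Compound 3 `Cc1c(-c2noc(-c3cc(O)c(O)c([N+](=O)[O-])c3)n2)ccc(C(F)(F)F)[n+]1[O-]` gives 13.9%.

All three were tested in a functional assay on the whole organism (liver, strain Wistar) for inhibition, with Rattus norvegicus as the target, with a stated time of 3 h, at a dose of 3 mg/kg by the oral route; on this read-out higher numbers stand for more inhibition at the one dose given (going by the name of the read-out) and lower numbers for less inhibition. The values of compound 1 and compound 3 are level at the digits given, and the value of compound 2 lies within the usual scatter of both, so no ranking among the three can be drawn from these numbers.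

Compound 2 and compound 1 differ in one place, (hydrogen in place of methyl on an aromatic carbon), and on this read-out the step was a number 6 percentage points higher from compound 2 to compound 1 (within the scatter). The core of compound 3 differs from the core of compound 2 in more ways than one, and that difference is not broken down here.

Compound 4 `O=[N+]([O-])c1cc(-c2nc(-c3ccc(C(F)(F)F)[n+]([O-])c3)no2)cc(O)c1O` has not yet been measured. It is made from compound 3 by the same kind of change, (hydrogen in place of methyl on an aromatic carbon). The surroundings are not the same: in compound 2 the methyl that leaves is ortho to two methyl groups, two atoms from the ring nitrogen, meta to a group of 1 heavy atom, meta to a large group and para to a chloro group, whereas in compound 3 it is next to the ring nitrogen, ortho to a group of 1 heavy atom, ortho to a large group and meta to a trifluoromethyl group.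

Since the earlier step of a number 6 percentage points higher from compound 2 to compound 1 (within the scatter) stayed within the scatter, the step expected here is a number 3.1 percentage points higher from compound 3 to compound 4 (within the scatter), and compound 4 is estimated at 17%, most likely between 4% and 32%.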

Compound 4, a percentage reported as inhibition, in the whole organism at one dose (the size of the read-out at that dose, not a potency): 34.4%
Compound 4: the middle estimate sits 17.4 percentage points below what was measured, and the stated range ends below it.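

On the core of compound 3, putting hydrogen in place of methyl next to the ring nitrogen gave a number 20.5 percentage points higher from compound 3 to compound 4 (beyond the scatter), a real though modest gain in this assay. The same kind of change did not carry over with the same size from one core to the other: the same change on two cores in this assay, a number 6 percentage points higher (within the scatter) from compound 2 to compound 1 and a number 20.5 percentage points higher (beyond the scatter) from compound 3 to compound 4, 14.5 percentage points apart, beyond the scatter of two such steps. For the compounds shown here, this shows that a step measured on one core is a poor guide to its size on another, but with only two pairs it sets no general rule, and it does not show which of the many differences in the surroundings of the methyl matters, nor how the change would affect potency, as the read-out reflects a single oral dose.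

The compounds shown leave open what a group other than hydrogen or methyl would do at this carbon, for example an ethyl group, a methoxy group or an amine, and so whether hydrogen is special there or any replacement of the methyl would serve as well. They also leave open whether the gain seen on the core of compound 3 would return on a third core, or would fall closer to the smaller step.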